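Amide-Capping Change from Aryl to Oxocyclobutyl

The source may hold more compounds than are shown below. What is called first, only, known or untested is meant among the compounds shown, and "the series" means these compounds.

Compound 1 `CC(=O)c1cc(C(=O)N[C@H](C)Cn2ccc(-c3cc(F)c(C#N)c(Cl)c3)n2)n[nH]1` — 1080 nM
Compound 2 `CC(O)c1cccc(C(=O)N[C@@H](C)Cn2ccc(-c3ccc(C#N)c(Cl)c3)n2)c1` — 2280 nM

Within the data shown here, in a functional assay on LNCaP cells (Homo sapiens) for antiproliferative activity, read by CCK-8 assay, with a stated time of 6 days (on this read-out lower numbers stand for stronger inhibition and higher numbers for weaker inhibition), compound 2 gives the higher of the two numbers, with compound 1 as its only neighbour at the lower value. Compound 3 `C[C@@H](Cn1ccc(-c2ccc(C#N)c(Cl)c2)n1)NC(=O)C1CC(=O)C1` differs from compound 2 by 3-oxocyclobutyl in place of 3-(1-hydroxyethyl)phenyl on a carbonyl carbon. Among the measured compounds shown here, no measured pair shows this kind of exchange, so its effect is not established. Compound 3 is expected to lose some potency, an estimated step of a 1.8-fold higher number from compound 2 to compound 3 (0.24 log units; within the scatter) in this assay. Compound 3 is therefore estimated at 4000 nM, within a range from 1200 nM to 15000 nM.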

Compound 3, half-maximal inhibitory concentration: 3040 nM
For compound 3 the middle estimate is 1.3-fold (0.12 log units) above the measured one, within the range that was stated.
By their numbers in this assay, from the lowest: compound 1; then compounds 2 and 3 (each within the scatter of the next).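

Exchanging the 3-(1-hydroxyethyl)phenyl on the carbonyl carbon for 3-oxocyclobutyl in this assay gives a 1.3-fold higher number from compound 2 to compound 3 (0.12 log units; within the scatter). The amide cap at this position therefore need not be a six-membered aromatic ring or carry a hydrogen-bond donor to keep the number within the scatter, and the smaller four-membered ring serves as well here. No available evidence accounts for this result.

As far as these compounds go, it remains open whether a cap bearing an amine or a carboxylic acid on this carbonyl carbon would change the number in this assay. The same question stands for a longer open alkyl chain.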